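The source may hold more compounds than are shown below. What is called first, only, known or untested is meant among the compounds shown, and "the series" means these compounds.

In a functional assay on Bel-7402 cells (Homo sapiens) for antiproliferative activity, read by MTT assay, with a stated time of 72 h (a lower number here means a stronger inhibitor, a higher number a weaker inhibitor), compound 1 (`COc1ccc(Cn2c(C(=O)O)c(CNCc3cccc(O)c3)c3ccccc32)cc1`) gives > 50000 nM, which is a limit and not a number. Compound 3 (`COc1ccc(Cn2c(C(=O)O)c(CNCc3ccc(O)c(OC)c3)c3ccccc32)cc1`) gives > 50000 nM, also a limit. Compound 2 (`COc1ccc(Cn2c(C(=O)O)c(CNCc3cccc(OC)c3)c3ccccc32)cc1`) gives 52900 nM. Compound 4 (`COc1ccc(Cn2c(C(=O)O)c(CNCc3cccc(O)c3)c3ccc(C)cc32)cc1`) departs from compound 1 by methyl in place of hydrogen on an aromatic carbon. Three measured steps are available: a step that the limit leaves unreadable from compound 1 to compound 2, a step that the two limits leave unreadable from compound 1 to compound 3 and a step that the limit leaves unreadable from compound 2 to compound 3. None has a readable size, and none makes this change. What remains is the limit of > 50000 nM in this assay, at which 2 of the 3 values shown sit. No step beyond the scatter is therefore expected in this assay, and no direction can be argued, so the estimated step is an at least 1.1-fold lower number from compound 1 to compound 4 (0.04 log units; that floor lies within the scatter). For compound 4 the expected value is 45000 nM, with an estimated range of 15000 nM to 90000 nM.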

Compound 4, half-maximal inhibitory concentration: 19800 nM
The estimate for compound 4 lay 2.3-fold (0.36 log units) above the measured number; measured number inside the range.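

In this assay, among these compounds, this position on the fused system, meta to a fused ring and para to a fused ring, gives the first readable effect, an at least 2.5-fold lower number from compound 1 to compound 4 (0.40 log units; beyond the scatter), whereas the earlier steps cannot be read. A single methyl in place of hydrogen on this aromatic carbon is therefore enough to move the number beyond the scatter. The size is only a floor, since the value for compound 1 is a limit: the limit of > 50000 nM in this assay, at which 2 of the 4 values shown sit.

On these data alone, whether chloro, methoxy or ethyl at this carbon would act like methyl stays open. So does whether methyl would have the same effect on another carbon of that ring.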